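The source may hold more compounds than are shown below. What is called first, only, known or untested is meant among the compounds shown, and "the series" means these compounds.

The measured compounds:
compound 1 `CC(C)n1ncc2c(C(=O)NCc3cn(-c4ccc(I)cc4)nn3)cccc21` — > 40000 nM
compound 2 `CC(C)n1ncc2c(C(=O)NCc3cn(-c4ccc(C(F)(F)F)cc4)nn3)cccc21` — > 40000 nM

In a functional assay on HepG2 cells (Homo sapiens) for inhibition, read by MTT assay, with a stated time of 72 h (a lower number here means a stronger inhibitor, a higher number a weaker inhibitor), compound 1 gives > 40000 nM, which is a limit of the assay and not a number. In this assay compound 2 gives > 40000 nM, likewise a limit. Both values sit at the limit of > 40000 nM in this assay, at which 2 of the 2 values shown sit, so the step that the two limits leave unreadable from compound 1 to compound 2 cannot be read in either direction, and compound 2 stands only at that limit, with no number to place it.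

Compound 3 `CCc1ccc(-n2cc(CNC(=O)c3cccc4c3cnn4C(C)C)nn2)cc1` differs from compound 2 in one place: ethyl in place of trifluoromethyl on an aromatic carbon. Among the measured compounds shown here, the only measured step at the same position is the one from compound 1 to compound 2, and its size is not readable, so it gives no direction for the change to ethyl. With both neighbours at the limit, compound 3 is expected to remain there as well; the step that the limit leaves unreadable from compound 2 to compound 3 is expected to be none beyond the scatter. Compound 3 is therefore estimated at 60000 nM, within a range from 20000 nM to 200000 nM, and most probably the assay will again report only a limit.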

Compound 3, half-maximal inhibitory concentration: > 40000 nM
Compound 3: only a limit was reported; the forecaster's own chance of this, stated with the estimate: 85%; the middle value does not contradict the limit.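

In this assay compound 3 gives > 40000 nM, which is a limit of the assay and not a number. No step among compound 1, compound 2 and compound 3 can be read, because all three stand at the same limit: the limit of > 40000 nM in this assay, at which 3 of the 3 values shown sit.

The compounds shown leave open whether any group at this aromatic carbon gives a readable value in this assay.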